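The compounds below may be only part of what the source reports. "The series", "measured", "known", "first", "only" and "open" are said of these compounds alone.

Three related compounds have been tested for their toxicity to liver-derived cells in an ADME assay on L02 cells (Homo sapiens) for cytotoxicity, read by MTT assay, with a stated time of 48 h; on this read-out higher numbers stand for weaker inhibition and lower numbers for stronger inhibition. In this assay compound 1 `O=[N+]([O-])c1cc(-c2nc3ccc([N+](=O)[O-])cc3[nH]2)cc(-c2nc3ccc([N+](=O)[O-])cc3[nH]2)c1` gives 44900 nM. In this assay compound 2 `Clc1ccc2nc(-c3cccc(-c4nc5ccc(Cl)cc5[nH]4)c3)[nH]c2c1` gives 13700 nM. In this assay compound 3 `FC(F)(F)c1ccc2nc(-c3cccc(-c4nc5ccc(C(F)(F)F)cc5[nH]4)c3)[nH]c2c1` gives 10900 nM, the lowest of the three numbers. The gap between compound 3 and compound 2 lies within the usual scatter of such measurements, so these two cannot be ranked against each other, while the gap between compound 3 and compound 1 lies beyond the scatter.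

Compound 4 `O=[N+]([O-])c1cc(-c2nc3ccc(C(F)(F)F)cc3[nH]2)cc(-c2nc3ccc(C(F)(F)F)cc3[nH]2)c1` has not yet been measured. It differs from compound 3 in one place: nitro in place of hydrogen on an aromatic carbon. For the measured compounds named here, no pair of measured compounds isolates this change. Compound 1 carries the same group on its central ring and shows the highest number, yet it also differs from compound 3 in the groups on the outer rings, so its value alone cannot tell the effect of the nitro group. A modest step toward a higher number, a 1.7-fold higher number from compound 3 to compound 4 (0.22 log units; within the scatter), is expected in this assay. For compound 4 the expected value in this assay is 18000 nM, with a range from 7000 nM to 45000 nM.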

Compound 4, half-maximal inhibitory concentration: 3700 nM
Compound 4: the middle estimate sits 4.9-fold (0.69 log units) above what was measured; the measured number lies below the stated range.
By their numbers in this assay, from the lowest: compound 4; then compounds 3 and 2 (each within the scatter of the next); then compound 1.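

In this assay, for the compounds shown here, this is the first pair to isolate a single change: nitro in place of hydrogen on an aromatic carbon, meta to two large groups, gives a 2.9-fold lower number from compound 3 to compound 4 (0.47 log units; beyond the scatter). The step is modest but beyond the scatter, so with trifluoromethyl elsewhere on the core, this change goes with stronger inhibition. It holds for this pair only: compound 1 also carries nitro at this place but has other outer groups and gives 44900 nM, so the nitro group alone does not set the number, and nothing available explains the step.

As far as these compounds go, whether an amine or a carboxylic acid on the same carbon would move the number in the same direction remains open. Also open, from the compounds shown here alone, is whether nitro would give a similar step on the core of compound 2, which carries chlorine instead of trifluoromethyl.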